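Cyclopropylcarbonyl for isopropoxycarbonyl: expected plasma half-life

The compounds below may be only part of what the source reports. "The series", "measured", "known", "first", "only" and "open" are said of these compounds alone.

The series shares one core with a methylsulfonylphenyl group, two ring nitrogens each carrying an acyl or carbamate, and a methyl on the ring carbon. Compound 3, `CC(=O)N1c2ccc(-c3ccc(S(C)(=O)=O)cc3)cc2N(C(=O)OC(C)C)C[C@@H]1C`, gives 0.1 h in an ADME assay on a cell-free system (plasma, Mus musculus) for metabolic stability (on this read-out higher numbers stand for a longer-lived compound and lower numbers for a shorter-lived compound), the lowest of the two numbers measured; the nearest is compound 2, `CCC(=O)N1c2ccc(-c3ccc(S(C)(=O)=O)cc3)cc2N(C(=O)c2ccco2)C[C@@H]1C`, which in this assay gives 0.3 h, a gap beyond the scatter. Compound 1, `C[C@H]1CN(C(=O)c2ccco2)c2cc(-c3ccc(S(C)(=O)=O)cc3)ccc2N1C(=O)C1CC1`, reaches only a limit of the assay, > 0.4 h in this assay; see (the limit of > 0.4 h in this assay, at which 1 of the 3 values shown sits).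

Compound 4, `CC(=O)N1c2ccc(-c3ccc(S(C)(=O)=O)cc3)cc2N(C(=O)C2CC2)C[C@@H]1C`, differs from compound 3 by cyclopropyl in place of isopropoxy on a carbonyl carbon. Within the data shown here, the only measured step on a carbonyl substituent is an at least 1.3-fold lower number from compound 1 to compound 2 (0.12 log units; that floor lies within the scatter), where the cyclopropyl carried the longer-lived number, though its size is bounded only by a limit and its floor lies within the scatter. Among the measured compounds shown here, that step swaps cyclopropyl against ethyl; no measured pair swaps cyclopropyl against isopropoxy, so the direction is taken from compound 1 and compound 2 and the size remains open.

On that basis an increase from compound 3 to compound 4 is expected in this assay, a 3.0-fold higher number from compound 3 to compound 4 (0.48 log units; beyond the scatter), probably beyond the scatter but not by much. The estimated value for compound 4 in this assay is 0.3 h, within 0.1 h to 0.8 h.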

Compound 4, half-life: > 0.4 h
Compound 4: a limit, no number (the forecaster's own chance of this, stated with the estimate: 15%); middle value at least 1.3-fold (0.12 log units) from the limit.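

Notes on the carbonyl substituent: this is the first measured exchange of a carbamate for an amide on a carbonyl carbon whose other neighbours are an amide-type nitrogen in a ring. In this assay, among these compounds, the change reads an at least 4.0-fold higher number from compound 3 to compound 4 (0.60 log units; beyond the scatter), so even its floor clears the scatter, whereas the floor of the only earlier step on a carbonyl substituent, which swapped cyclopropyl against ethyl, stayed within it. Compound 4 gives > 0.4 h, which is a limit of the assay and not a number, so the step fixes the direction and a minimum size but no upper size, and the top of the read-out now constrains the series: the limit of > 0.4 h in this assay, at which 2 of the 4 values shown sit.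

Still open is whether the higher number goes with the loss of isopropoxy or with the entry of cyclopropyl, as the compounds shown offer only this one exchange at this carbonyl with the rest of the molecule held constant. Also open, on these data alone, is how a longer chain, such as butyl, or an amine on the same carbonyl carbon would read on this half-life, and how far above the limit compound 4 truly lies.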